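From a Furan to an Open Chain on the Shared Core

The source may report more compounds than this note shows. Statements on the series, on what has been measured and on what is new or still open speak of the compounds shown alone.

Compound 1 `COc1ccc(/C=C/c2ncnc3c2ncn3C2CCOCC2)cc1` and compound 2 `C(=C/c1ncnc2c1ncn2C1CCOCC1)\c1ccco1` share one core and differ only at the end of the chain. In a functional assay on K562 cells (Homo sapiens) for inhibition, read by thymidine incorporation, with a stated time of 48 h, tested at 10 ug/mL (on this read-out higher numbers stand for more inhibition at the one concentration tested (going by the name of the read-out) and lower numbers for less inhibition), compound 1 gives 58%, while compound 2 gives 35%, the lower of the two numbers; that step is a number 23 percentage points lower from compound 1 to compound 2 (beyond the scatter). Compound 3 `C/C(=C\C=C\c1ncnc2c1ncn2C1CCOCC1)CO` carries 2-(hydroxymethyl)prop-1-en-1-yl in place of furan-2-yl on a double-bonded chain carbon bound to a double-bonded chain carbon. Among the measured compounds shown here, no measured step trades a ring for an open chain, so the one step known is only a loose guide. Compound 3 is therefore expected to change by a number 5 percentage points lower from compound 2 to compound 3 (within the scatter). For compound 3 the estimate is 30%, with a range from 10% to 55%.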

Compound 3, a percentage reported as inhibition, at one concentration (the size of the read-out at that concentration, not a potency): 27%
Beside the measured number, compound 3's estimate is 3 percentage points above it; the measured number falls inside the stated range.
By their numbers in this assay, from the lowest: compounds 3 and 2 (each within the scatter of the next); then compound 1.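

In this assay, the open 2-(hydroxymethyl)prop-1-en-1-yl chain in place of furan-2-yl gives a number 8 percentage points lower from compound 2 to compound 3 (within the scatter) and so shows that, at this place, an open chain reads within the scatter of the five-membered aromatic ring. Against 4-methoxyphenyl the same chain gives a number 31 percentage points lower from compound 1 to compound 3 (beyond the scatter) and so leaves the gap to compound 1 beyond the scatter, as it was with furan-2-yl. No measurement offered here accounts for either step.

The compounds shown leave open whether a chain ending in an amine or a carboxylic acid, or a longer chain, would read differently at this place.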